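Amino-substituent change on the shared core: compound 2 to compound 4

The compounds below may be only part of what the source reports. "The series", "measured", "known", "first", "only" and "open" are said of these compounds alone.

Measured so far:
compound 1 `CCCCC(CC)Nc1nc(C)nc2c1nnn2-c1c(C)cc(C)cc1C`: 7.6 nM
compound 2 `CCN(c1nc(C)nc2c1nnn2-c1ccc(C(C)C)cc1Br)C(COC)COC`: 123 nM
compound 3 `CCCCN(CC)c1nc(C)nc2c1nnn2-c1ccc(SC)cc1Br`: 10.6 nM

In an in vitro assay on 293-EBNA cells for binding affinity to corticotropin-releasing factor receptor 1 (Homo sapiens) (a higher number here means a weaker inhibitor, a lower number a stronger inhibitor), compound 1 gives 7.6 nM and compound 3 gives 10.6 nM, while compound 2 gives 123 nM, the highest of the three numbers; its gap to compound 3 and its gap to compound 1 both lie beyond the scatter.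

Compound 4 `CCC(CO)Nc1nc(C)nc2c1nnn2-c1ccc(C(C)C)cc1Br` is not yet measured. It differs from compound 2 only in the amino substituent on the shared core: a group of 6 heavy atoms (4 carbon, 1 nitrogen, 1 oxygen; no ring) in place of a group of 10 heavy atoms (7 carbon, 1 nitrogen, 2 oxygen; no ring), on an aromatic carbon. The aryl group on the core is unchanged from compound 2. For the measured compounds named here, an amino substituent with a hydrogen on nitrogen is found in compound 1, which gives 7.6 nM; the hydroxymethyl group of compound 4 has no counterpart among the measured compounds, so the range must stay wide.

The step from compound 2 to compound 4 is expected to be a 4.1-fold lower number from compound 2 to compound 4 (0.61 log units; beyond the scatter), toward a lower number and beyond the scatter. Compound 4 is estimated at 30 nM, with a range from 8 nM to 120 nM.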

Compound 4, inhibition constant: 25.3 nM
The estimate for compound 4 lay 1.2-fold (0.07 log units) above the measured number; low and high end bracket the measured number.
By their numbers in this assay, from the lowest: compounds 1 and 3 (each within the scatter of the next); then compound 4; then compound 2.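

In this assay, for the compounds shown here, with the aryl group held fixed, the (1-(hydroxymethyl)propyl)amino group in place of the larger open-chain substituent of compound 2 gives a 4.9-fold lower number from compound 2 to compound 4 (0.69 log units; beyond the scatter) and provides the first single-place comparison. This shows that the amino substituent alone can move the number beyond the scatter. The change lowers the heavy-atom count and raises the hydrogen-bond donor count together, so this single step cannot separate the two, and no measurement here explains the shift.

Still open, on these data alone, is whether the hydroxyl group matters, which a methoxymethyl group or a plain propyl chain at the same branch point would test. As far as these compounds go, it is also open whether the same amino-group change carries over to the aryl groups of compound 1 and compound 3.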